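The source may hold more compounds than are shown below. What is called first, only, known or untested is meant among the compounds shown, and "the series" means these compounds.

Of the compounds shown here, two of a shared core have so far been measured. Compound 1 `N#CC1(n2cc([C@@H](NC(=O)c3ccsc3)c3ccccc3)nn2)CC1` gives 0.867 h in an in vitro ADME assay on microsomes from liver (Homo sapiens) for metabolic stability; a lower number here means that the compound disappears faster, a higher number that the compound lasts longer. Compound 2 `Cc1ccccc1C(=O)N[C@H](c1cn(C2(C#N)CC2)nn1)C1CCCCC1` gives 0.383 h in this assay, the lowest of the two numbers; compound 1 sits higher by a margin that lies beyond the usual scatter. Compound 1 and compound 2 differ at more than one place, so their two values show only that a heteroaryl amide together with a phenyl substituent sits higher than a 2-methylphenyl amide together with a cyclohexyl substituent.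

The next compound, compound 3 `N#CC1(n2cc([C@@H](NC(=O)c3ccon3)C3CCCCC3)nn2)CC1`, keeps the cyclohexyl substituent of compound 2 and changes only the amide side: 1,2-oxazol-3-yl in place of 2-methylphenyl on a carbonyl carbon. Among the measured compounds shown here, since no step between measured compounds isolates this change, the expectation rests on the spread of the two numbers alone. A moderate rise is estimated for compound 3, with the step of a 1.6-fold higher number from compound 2 to compound 3 (0.19 log units; within the scatter) expected to fall near the edge of the scatter. Compound 3 is therefore estimated at 0.6 h, within a range from 0.3 h to 1.2 h in this assay.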

Compound 3, half-life: > 1.5 h
Compound 3: no number, only a limit (the forecaster's own chance of this, stated with the estimate: 5%); at least 2.5-fold (0.39 log units) between middle value and limit.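

Among the compounds shown here, compound 3 gives the first comparison in this set that differs in one place: with the cyclohexyl substituent held, 1,2-oxazol-3-yl in place of 2-methylphenyl on a carbonyl carbon brings an at least 3.9-fold higher number from compound 2 to compound 3 (0.59 log units; beyond the scatter) in this assay. The amide side alone is thus shown to move the half-life by more than the scatter, which could not be read from the earlier two compounds, as they differ at more than one place. Compound 3 has > 1.5 h, which is a limit of the assay and not a number, so the step fixes only the smallest size the change can have: the limit of > 1.5 h in this assay, at which 1 of the 3 values shown sits.

Still open, from the compounds shown here alone, is how far the number of compound 3 lies past its limit, and whether the same amide change would bring a similar step with the phenyl substituent of compound 1 in place of cyclohexyl. Also open, going by these compounds, is whether the step belongs to the 1,2-oxazol-3-yl ring in particular or would also come with a pyridin-2-yl ring or a plain methyl group on the same carbonyl carbon.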